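This account rests on a few compounds, and the source may have more. Where it says the series, first, only, none or still open, it means among the compounds named here.

The measured compounds:
Compound 1 `Cn1cc(-c2cnc(NCc3c(F)ccc4c3CCO4)c3cn[nH]c(=O)c23)cn1` gives 21 mL.min-1.g-1 in an ADME assay on microsomes from liver (Homo sapiens) for metabolic stability, read by LC-MS, using NADPH, with stated times of 5 min and 30 min, tested at 1 uM; on this read-out higher numbers stand for fast clearance and lower numbers for slow clearance.
Compound 2 `CN(C)Cc1ccc2c(c1)CN(c1cnc(NCc3c(F)ccc4c3CCO4)c3cn[nH]c(=O)c13)C2=O` gives 32 mL.min-1.g-1 in this assay.

Compound 1 holds the lower of these two numbers, and its nearest neighbour is compound 2, but the gap between them lies within the usual scatter of the measurement, so the two compounds cannot be told apart on this read-out. Among the compounds with values here, no pair of measured compounds differing in a single place is available, so no measured step can guide the next compound.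

Compound 3 `Cc1ncc(-c2cnc(NCc3c(F)ccc4c3CCO4)c3cn[nH]c(=O)c23)n1C` has not yet been tested in this assay. It differs from compound 1 in one place: 1,2-dimethyl-1H-imidazol-5-yl in place of 1-methyl-1H-pyrazol-4-yl on an aromatic carbon. With nothing measured around this change, only a small step is expected, possibly none beyond the scatter. The estimate for compound 3 is 26 mL.min-1.g-1, with a range from 12 mL.min-1.g-1 to 55 mL.min-1.g-1. That estimate implies an expected step of a 1.2-fold higher number from compound 1 to compound 3 (0.09 log units; within the scatter).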

Compound 3, intrinsic clearance in microsomes: 10 mL.min-1.g-1
The estimate for compound 3 lay 2.6-fold (0.41 log units) above the measured number; the measured number lies below the stated range.
By their numbers in this assay, from the lowest: compound 3; then compounds 1 and 2 (each within the scatter of the next).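

At this aromatic carbon, para to a large group, the five-membered aromatic ring can be exchanged with a measurable result in this assay: 1,2-dimethyl-1H-imidazol-5-yl in place of 1-methyl-1H-pyrazol-4-yl gives a 2.1-fold lower number from compound 1 to compound 3 (0.32 log units; beyond the scatter), a modest step and the only single-place change shown in this series. The two groups match in hydrogen-bond donors, hydrogen-bond acceptors and net charge, so these counts do not separate them, yet the clearance still differs beyond the scatter. Nothing measured here accounts for the step.

The compounds shown do not tell whether the step follows the change of ring or the added methyl, and a 1-methyl-1H-imidazol-5-yl group at the same carbon would separate the two. They also leave open how a six-membered ring such as pyridine or an amine such as morpholine would fare there.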